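The source may report more compounds than this note shows. Statements on the series, on what has been measured and on what is new or still open speak of the compounds shown alone.

Measured compounds:
Compound 1 `CCCc1noc(C2CCN(c3ncnc(Nc4ccc(S(C)(=O)=O)cc4)c3[N+](=O)[O-])CC2)n1` — in a functional assay for agonist activity at Glucose-dependent insulinotropic receptor (Homo sapiens) (on this read-out higher numbers stand for an effect only at larger amounts of compound and lower numbers for an effect already at smaller amounts), compound 1 gives 430 nM.
Compound 2 `CCS(=O)(=O)c1ccc(Nc2ncnc(N3CCC(c4nc(C(C)C)no4)CC3)c2[N+](=O)[O-])cc1` — in this assay compound 2 gives 17 nM.

For the measured compounds named here, of the two compounds measured so far, compound 2 has the lower number in this assay; its nearest neighbour is compound 1, whose number is higher by a gap that lies beyond the usual scatter. Going by the values given here, no single-change step links compound 1 and compound 2, so nothing more than the two values themselves can be said about what separates them.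

Compound 3 `CC[S+]([O-])c1ccc(Nc2ncnc(N3CCC(c4nc(C(C)C)no4)CC3)c2[N+](=O)[O-])cc1` has not yet been measured. It differs from compound 2 in one place: a group of 4 heavy atoms (2 carbon, 1 oxygen, 1 sulfur; no ring) in place of a group of 5 heavy atoms (2 carbon, 2 oxygen, 1 sulfur; no ring), on an aromatic carbon, para to a large group.

Among the compounds with values here, since no step between measured compounds is available, the expectation rests on the change alone. The expected step is a 2.9-fold higher number from compound 2 to compound 3 (0.47 log units; beyond the scatter), a modest rise that may or may not exceed the scatter. For compound 3 the estimate in this assay is 50 nM, with a range from 15 nM to 200 nM.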

Compound 3, half-maximal effective concentration: 17.1 nM
Compound 3: middle estimate off by 2.9-fold (0.47 log units), on the high side; the measured number falls inside the stated range.
By their numbers in this assay, from the lowest: compounds 2 and 3 (each within the scatter of the next); then compound 1.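

At the aromatic carbon para to a large group, the ethylsulfonyl of compound 2 gives way to the group of 4 heavy atoms (2 carbon, 1 oxygen, 1 sulfur) in compound 3, and in this assay this exchange amounts to a 1.0-fold higher number from compound 2 to compound 3 (0.00 log units; within the scatter). For the compounds shown here, this is the first single-change step, and it shows that the read-out does not separate these two groups at this position, something the earlier pair, which differs in more than one place, could not show. No measurement of any further property accompanies this step, so nothing here accounts for it.

As far as these compounds go, it remains open whether a simple ethylthio group, with no oxygen on the sulfur, or a different group such as a carboxylic acid or an amine at this position would also leave the number within the scatter of compound 2. From the compounds shown here alone, it also remains open how much of the gap between compound 1 and compound 2 belongs to the chain on the sulfonyl group and how much to the alkyl group on the other end of the molecule.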